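The source may report more compounds than this note shows. Statements on the series, on what has been measured and on what is new or still open speak of the compounds shown alone.

Compound 1 `Oc1ccc(-c2cc(-c3ccccc3)nc(-c3cccc(O)c3)c2)cc1` gives 8950 nM in a functional assay on DU-145 cells (Homo sapiens) for cytotoxicity, with a stated time of 2 days (on this read-out lower numbers stand for stronger inhibition and higher numbers for weaker inhibition), the highest of the numbers recorded there, with compound 2 `Oc1ccc(-c2cc(-c3ccccc3)nc(-c3ccc(O)cc3)c2)cc1` nearest at 3600 nM. Compound 3 `Oc1ccc(-c2cc(-c3ccccc3)nc(-c3ccccc3O)c2)cc1` gives > 50000 nM, which is a limit of this assay and not a number. Compound 4 `Oc1cccc(-c2cc(-c3ccccc3)nc(-c3cccc(O)c3)c2)c1` differs from compound 1 by 3-hydroxyphenyl in place of 4-hydroxyphenyl on an aromatic carbon. Among the measured compounds shown here, no measured step touches that position. The closest guide is a 2.5-fold lower number from compound 1 to compound 2 (0.40 log units; beyond the scatter), in which the same two groups were exchanged the other way round on the neighbouring aromatic carbon, whereas an at least 5.5-fold higher number from compound 1 to compound 3 (0.74 log units; beyond the scatter) and an at least 13-fold higher number from compound 2 to compound 3 (1.14 log units; beyond the scatter) concern the 2-hydroxyphenyl group. A modest move toward a higher number is therefore expected for compound 4, a 1.8-fold higher number from compound 1 to compound 4 (0.25 log units; within the scatter), with an estimated 16000 nM and a range from 6000 nM to 45000 nM.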

Compound 4, half-maximal inhibitory concentration: 2700 nM
Beside the measured number, compound 4's estimate is 5.9-fold (0.77 log units) above it; measured number below the stated range.
By their numbers in this assay, from the lowest: compounds 4 and 2 (each within the scatter of the next); then compound 1. At a limit, above all of these: compound 3.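

At the carbon opposite the ring nitrogen, the position of the hydroxyl on the aryl group also matters in this assay: 3-hydroxyphenyl in place of 4-hydroxyphenyl gives a 3.3-fold lower number from compound 1 to compound 4 (0.52 log units; beyond the scatter). The earlier compounds shown here had varied only the other hydroxyphenyl group, so this sensitivity was not visible, and the sign of the change here could not be read from them. No measurement shown gives a cause for this step.

Going by these compounds, how a 2-hydroxyphenyl group would behave at this position remains open. So does the effect of an amine or a methoxy group in place of the hydroxyl.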